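From 1,3-benzothiazol-2-yl to 1,3-benzoxazol-2-yl at the assay limit

A few compounds are considered here, and "the series" means these few. Any claim that something is new, unique, unknown or untested is made for them only; others in the source may bear on it.

Compound 3 `O=C(Nc1cc(-c2nc3ccccc3s2)ccc1F)c1cc([N+](=O)[O-])ccc1Cl` gives > 25000 nM in an ADME assay on Raji cells (Homo sapiens) for cytotoxicity, with a stated time of 72 h (a lower number here means that less compound is needed, a higher number that more compound is needed for the effect), which is a limit and not a number. Compound 2 `O=C(Nc1cc(-c2nc3ccccc3s2)ccc1Cl)c1cc([N+](=O)[O-])ccc1Cl` gives > 25000 nM, also a limit. Compound 1 `O=C(Nc1cccc(-c2nc3ccccc3o2)c1)c1cc([N+](=O)[O-])ccc1Cl`, which already carries 1,3-benzoxazol-2-yl but no fluoro group, gives > 25000 nM, again a limit. Within the data shown here, the only measured step, a step that the two limits leave unreadable from compound 2 to compound 3, has no readable size. Compound 4 `O=C(Nc1cc(-c2nc3ccccc3o2)ccc1F)c1cc([N+](=O)[O-])ccc1Cl` has 1,3-benzoxazol-2-yl in place of 1,3-benzothiazol-2-yl on an aromatic carbon, (1,3-benzoxazol-2-yl in place of 1,3-benzothiazol-2-yl on an aromatic carbon). Going by the limit of > 25000 nM in this assay, at which 3 of the 3 values shown sit, no step beyond the scatter is expected in this assay. The estimated step is a step that the limit leaves unreadable from compound 3 to compound 4. Compound 4 is expected near 30000 nM, with an estimated range from 12000 nM to 60000 nM.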

Compound 4, half-maximal effective concentration: > 25000 nM
Compound 4 was reported as a limit; the forecaster's own chance of this, stated with the estimate: 85%; the middle value lies beyond the limit too.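

Compound 4 is also a limit, so neither its step from compound 3 nor its step from compound 1 can be read: the limit of > 25000 nM in this assay, at which 4 of the 4 values shown sit. The compounds shown leave open what concentration any of them needs in this assay, and whether either change matters.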